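Replacing a Hydroxylated Side Chain with an Aldehyde

The source may report more compounds than this note shows. Statements on the series, on what has been measured and on what is new or still open speak of the compounds shown alone.

Four compounds built on a shared core are compared in a functional assay on A549 cells (Homo sapiens) for cytotoxicity, read by MTT assay, with a stated time of 48 h; on this read-out lower numbers stand for stronger inhibition and higher numbers for weaker inhibition. Compound 1 `C=CC(=C)CC[C@@H]1[C@@]2(C)CCC[C@](C)(COC(=O)/C=C\c3ccc(O)cc3)[C@@H]2CC[C@@]1(C)O` gives 17100 nM, and compound 2 `C=CC(=C)CC[C@@H]1[C@@]2(C)CCC[C@](C)(COC(=O)/C=C/c3ccc(O)cc3)[C@@H]2CC[C@@]1(C)O` gives 20400 nM; their step, a 1.2-fold higher number from compound 1 to compound 2 (0.08 log units; within the scatter), is within the scatter, in line with the fact that compounds 1 and 2 differ only in the configuration as drawn. Compound 3 `C=C1CC[C@@H]2[C@](C)(CCC[C@]2(C)C(=O)O)[C@H]1CC/C(C)=C/CO` reaches only a limit in this assay, > 40000 nM, so no number is known for it; this is the limit of > 40000 nM in this assay, at which 1 of the 3 values shown sits. Compound 4 `C=C1CC[C@@H]2[C@](C)(CCC[C@]2(C)C(=O)O)[C@H]1C/C=C(\C)C=O` carries 2-formylprop-1-en-1-yl in place of 4-hydroxy-2-methylbut-2-en-1-yl on a saturated chain carbon bound to a saturated ring carbon. For the measured compounds named here, the single measured step concerns only a drawn configuration and offers no guide to this change. Compound 4 is therefore expected to stay weak, at an estimated 30000 nM with a range from 8000 nM to 80000 nM. That estimate corresponds to an expected step of an at least 1.3-fold lower number from compound 3 to compound 4 (0.12 log units; that floor lies within the scatter), with a real chance that only a limit is seen.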

Compound 4, half-maximal inhibitory concentration: > 40000 nM
Compound 4 ended at the assay's limit (the forecaster's own chance of this, stated with the estimate: 45%); at least 1.3-fold (0.12 log units) between middle value and limit.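

Compound 3 and compound 4 both end at a limit rather than a number, so no step between them can be read: the limit of > 40000 nM in this assay, at which 2 of the 4 values shown sit.

On these data alone, whether 2-formylprop-1-en-1-yl in place of 4-hydroxy-2-methylbut-2-en-1-yl changes cytotoxicity at all stays open.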